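Swapping the Aryl Group on the Ring Nitrogen

The compounds below may be only part of what the source reports. "The series", "measured", "known", "first", "only" and "open" are said of these compounds alone.

Among the measured compounds shown here, compound 2 `COc1ccc(-n2nc(-c3ccc(C(F)(F)F)cc3O)nc2-c2ccccc2O)cc1` stands at the lower of the two values measured so far, and in a functional assay on PC-12 cells (Rattus norvegicus) for cytotoxicity, read by MTT assay, with stated times of 2 h and 24 h, tested at 5 uM (on this read-out lower numbers stand for a weaker effect and higher numbers for a stronger effect at the one concentration tested), compound 2 gives 86.6%. For the measured compounds named here, its only neighbour, compound 1 `Oc1cc(C(F)(F)F)ccc1-c1nc(-c2ccccc2O)n(-c2ccc(F)cc2)n1`, lies within the scatter of it: in this assay compound 1 gives 86.7%. Going by the values given here, the single measured step, a number 0.1 percentage points lower from compound 1 to compound 2 (within the scatter), did not move the read-out beyond the scatter. Compound 3 `Cc1cc(C)cc(-n2nc(-c3ccc(C(F)(F)F)cc3O)nc2-c2ccccc2O)c1` differs from compound 2 by 3,5-dimethylphenyl in place of 4-methoxyphenyl on an aromatic nitrogen. Because a number 0.1 percentage points lower from compound 1 to compound 2 (within the scatter) stayed within the scatter, no step beyond the scatter is expected here either, which means an expected step of a number 1.6 percentage points lower from compound 2 to compound 3 (within the scatter). Compound 3 is therefore estimated at 85%, between 74% and 93%.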

Compound 3, a percentage reported as activity, at one concentration (the size of the read-out at that concentration, not a potency): 102%
For compound 3 the middle estimate is 17 percentage points below the measured one, and the stated range ends below it.
By their numbers in this assay, from the lowest: compounds 2 and 1 (each within the scatter of the next); then compound 3.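

Placing 3,5-dimethylphenyl on the ring nitrogen gave a number 15.4 percentage points higher from compound 2 to compound 3 (beyond the scatter) and a number 15.3 percentage points higher from compound 1 to compound 3 (beyond the scatter) in this assay and so showed that this position can move the read-out beyond the scatter, which the change from 4-fluorophenyl to 4-methoxyphenyl had not done. Nothing available here accounts for this higher number.

The compounds shown leave open whether a single methyl group on this phenyl ring would give the same higher number, and how an amine or a carboxylic acid in that place would read.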